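The source may hold more compounds than are shown below. What is called first, only, known or untested is meant among the compounds shown, and "the series" means these compounds.

Measured in a functional assay on A549 cells (Homo sapiens) for antiproliferative activity, read by MTT assay, with a stated time of 72 h; on this read-out lower numbers stand for stronger inhibition and higher numbers for weaker inhibition:
- compound 1 `Cc1noc(C)c1-c1nn(Cc2ccc(C(=O)NC3CC3)cc2)c(=O)c2ccccc12`: > 100000 nM, a limit
- compound 2 `Cn1cc(-c2nn(Cc3ccc(C(=O)NC4CC4)cc3)c(=O)c3ccccc23)cn1`: 51200 nM
- compound 3 `O=C(Nc1ccccc1Cl)c1ccc(Nc2nn(Cc3ccc(C(=O)NC4CCCCC4)cc3)c(=O)c3ccccc23)cc1`: > 100000 nM, a limit

Compound 1 has no number of its own, since compound 1 reads > 100000 nM, which is a limit of the assay. Compound 3 reads > 100000 nM, also a limit. The main feature of these data is the limit of > 100000 nM in this assay, at which 2 of the 3 values shown sit.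

Compound 4 `Cc1noc(C)c1-c1nn(Cc2ccc(C(=O)NC3CCN(C)CC3)cc2)c(=O)c2ccccc12` keeps the core of compound 1 and alters the amide: 1-methylpiperidin-4-yl in place of cyclopropyl on an amide-type nitrogen. In words, 1-methylpiperidin-4-yl takes the place of cyclopropyl on an amide-type nitrogen. Within the data shown here, the only measured step, an at least 1.9-fold lower number from compound 1 to compound 2 (0.29 log units; that floor lies within the scatter), concerns a different place in the molecule, so no measurement tests this change directly. Among the measured compounds shown here, compound 2, at 51200 nM, is the only measured number, and it gives no sign of strong inhibition in this assay. Compound 4 is therefore expected to stay weak, and it may also return only a limit. The estimated change is small: an at least 1.6-fold lower number from compound 1 to compound 4 (0.22 log units; that floor lies within the scatter). The estimate for compound 4 is 60000 nM, with an expected range from 15000 nM to 120000 nM.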

Compound 4, half-maximal inhibitory concentration: > 100000 nM
Compound 4 gave a limit, no number; the forecaster's own chance of this, stated with the estimate: 45%; middle value at least 1.6-fold (0.22 log units) away from the limit.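

Compound 1 and compound 4 each gave a limit rather than a number, so the step between them cannot be read, because the data sit at one ceiling: the limit of > 100000 nM in this assay, at which 3 of the 4 values shown sit.

On these data alone, it stays open whether 1-methylpiperidin-4-yl in place of cyclopropyl on the amide-type nitrogen changes the result in this assay at all.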